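Swapping a Bromophenyl for a Methoxyphenyl on the Amide

A few compounds are considered here, and "the series" means these few. Any claim that something is new, unique, unknown or untested is made for them only; others in the source may bear on it.

Among the measured compounds shown here, the two compounds measured so far share one core and differ only in the ring attached to the carbonyl. Compound 1 `CN(C(=O)c1ccccc1)c1ccc2[nH]c(-c3n[nH]c4ccccc34)cc2n1` gives 10600 nM in a functional assay on HCT-116 cells (Homo sapiens) for antiproliferative activity, read by MTT assay, with a stated time of 72 h (on this read-out higher numbers stand for weaker inhibition and lower numbers for stronger inhibition), and compound 2 `CN(C(=O)c1ccc(Br)cc1)c1ccc2[nH]c(-c3n[nH]c4ccccc34)cc2n1` gives 6110 nM. For the measured compounds named here, the only step recorded, a 1.7-fold lower number from compound 1 to compound 2 (0.24 log units; within the scatter), places compound 2 at the lowest of the two numbers, though within the scatter of compound 1.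

Compound 3 `COc1cccc(C(=O)N(C)c2ccc3[nH]c(-c4n[nH]c5ccccc45)cc3n2)c1` carries the change (3-methoxyphenyl in place of 4-bromophenyl on a carbonyl carbon). Going by the values given here, no measured step covers this particular swap; the one step available shows that adding a bromo to the ring moved the number little, which suggests the ring substituent is not a strong lever here. The expectation is therefore a step of a 1.3-fold higher number from compound 2 to compound 3 (0.12 log units; within the scatter), not beyond the scatter. Compound 3 is estimated at 8000 nM, within a range from 3000 nM to 22000 nM.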

Compound 3, half-maximal inhibitory concentration: 14200 nM
Compound 3: the middle estimate sits 1.8-fold (0.25 log units) below what was measured; the range from low to high includes it.
By their numbers in this assay, from the lowest: compounds 2, 1 and 3 (each within the scatter of the next, the first and the last beyond it).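

Swapping the ring on this carbonyl carbon can move the result beyond the scatter: the change gives a 2.3-fold higher number from compound 2 to compound 3 (0.37 log units; beyond the scatter), the first step in the series to do so, though it is modest. The methoxy group alone does not separate compound 3 from the plain phenyl ring, since adding it gives a 1.3-fold higher number from compound 1 to compound 3 (0.13 log units; within the scatter). The only clear gap therefore lies between the two substituted rings, with compound 1 within the scatter of both, and nothing available explains that gap.

The compounds shown leave open whether the gap follows the kind of group or its place on the ring, which a 4-methoxyphenyl or a 3-bromophenyl on the same carbonyl carbon would help to separate. As far as these compounds go, how an amine or a carboxylic acid on this ring would compare also remains open.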